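Swapping phenyl for pyridin-4-yl in a weak inhibitor

The compounds below may be only part of what the source reports. "The series", "measured", "known", "first", "only" and "open" are said of these compounds alone.

Measured in a functional assay on LNCaP cells (Homo sapiens) for antiproliferative activity, read by MTT assay, with a stated time of 24 h; a lower number here means a stronger inhibitor, a higher number a weaker inhibitor:
- Compound 1 `c1ccc(-c2noc(-c3ccncc3)n2)cc1`: 710000 nM
- Compound 2 `COc1ccc(-c2noc(-c3ccccc3)n2)cc1OC1CCCC1`: > 1000000 nM

Compound 2 gives only a limit, > 1000000 nM, and not a true number in this assay. Compound 3 `COc1ccc(-c2noc(-c3ccncc3)n2)cc1OC1CCCC1` keeps the rest of compound 2 but has pyridin-4-yl in place of phenyl on an aromatic carbon. For the measured compounds named here, no measured pair differs in one place, so the only guide is compound 1, which also carries pyridin-4-yl and gives 710000 nM. A modest shift toward stronger inhibition is expected, with an estimated at least 3.3-fold lower number from compound 2 to compound 3 (0.52 log units; beyond the scatter). The estimate for compound 3 is 300000 nM, with an expected range from 60000 nM to 1000000 nM.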

Compound 3, half-maximal inhibitory concentration: > 1000000 nM
Compound 3 was reported as a limit; the forecaster's own chance of this, stated with the estimate: 35%; middle value at least 3.3-fold (0.52 log units) from the limit.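

Compound 2 and compound 3 are both reported only as limits, so no step between them can be read, because both sit at the same ceiling: the limit of > 1000000 nM in this assay, at which 2 of the 3 values shown sit.

Going by these compounds, whether pyridin-4-yl in place of phenyl changes the activity of this shared core at all remains open.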